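The compounds below may be only part of what the source reports. "The series", "measured", "known", "first", "only" and "open" are said of these compounds alone.

Measured so far:
Compound 1 `COc1ccccc1C1C(C#N)=C(N)N(c2ccc(S(N)(=O)=O)cc2)C2=C1C(=O)CCC2`: 0%
Compound 2 `N#CC1=C(N)N(c2ccc(S(N)(=O)=O)cc2)C2=C(C(=O)CCC2)C1c1cccc([N+](=O)[O-])c1`: 50%

In a functional assay on Ehrlich cells (Mus musculus) for antiproliferative activity, read by trypan blue exclusion, with a stated time of 2 h, tested at 25 ug/mL (a lower number here means a weaker effect, a higher number a stronger effect of the compound at the concentration tested), compound 1 gives 0%, while compound 2 gives 50%. Among the measured compounds shown here, compound 2 therefore stands highest of the two numbers known, with compound 1 as its nearest neighbour at a markedly lower reading. For the measured compounds named here, the only step seen between these two is a number 50 percentage points higher from compound 1 to compound 2 (beyond the scatter), and it arises from an exchange of the aryl group on a saturated ring carbon of the shared core.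

Compound 3 `N#CC1=C(N)N(c2ccc(S(N)(=O)=O)cc2)C2=C(C(=O)CCC2)C1c1c(O)ccc2ccccc12` is not yet measured in this assay. It differs from compound 2 at that same place: 2-hydroxynaphthalen-1-yl in place of 3-nitrophenyl on a saturated ring carbon. Going by the values given here, the one measured step bears on it only insofar as it shows that exchanging the group on this saturated ring carbon can move the reading by a large amount; it says nothing about a 2-hydroxynaphthalen-1-yl group itself. Because of a number 50 percentage points higher from compound 1 to compound 2 (beyond the scatter), a sizeable shift in either direction cannot be excluded, and no direction is favoured by the numbers. Compound 3 is therefore estimated at 35%, within 5% to 70%, which means an expected step of a number 15 percentage points lower from compound 2 to compound 3 (beyond the scatter).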

Compound 3, a percentage reported as activity, at one concentration (the size of the read-out at that concentration, not a potency): 0%
Estimate against measurement, compound 3: 35 percentage points above, outside the stated range (below it).
By their numbers in this assay, from the lowest: compounds 1 and 3 (each within the scatter of the next); then compound 2.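

In this assay the exchange on this saturated ring carbon now moves the reading in both directions, with a number 50 percentage points lower from compound 2 to compound 3 (beyond the scatter), so the large effect seen earlier is not a rise that any new aryl group brings. Set against the 2-methoxyphenyl group, the 2-hydroxynaphthalen-1-yl group gives no change at the digits printed from compound 1 to compound 3 (within the scatter), and compound 2, with its 3-nitrophenyl group, gives 50%, the only reading among the three groups shown at this carbon that lies beyond the scatter of the others. Nothing on hand accounts for this difference between the groups.

Going by these compounds, whether the nitro group itself matters stays open, and an unsubstituted phenyl, or a phenyl carrying an amine or a carboxylic acid, at this carbon would bear on that. The cyano, amino and 4-sulfamoylphenyl groups are the same in all three compounds, so the compounds shown say nothing about an exchange at those places, such as a methyl ester in place of the nitrile.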